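Nitrothiophene glycine esters: replacing methoxy with fluoro

The source may report more compounds than this note shows. Statements on the series, on what has been measured and on what is new or still open speak of the compounds shown alone.

The series shares a core carrying a nitrothiophene arm, a benzylic arm and a tert-butyl ester. Compound 1 `CC(C)(C)OC(=O)CN(Cc1ccccc1)Cc1ccc([N+](=O)[O-])s1` has no result in a functional assay on HEK293 cells for agonist activity at nuclear receptor subfamily 1 group D member 1 (Homo sapiens), read by a luciferase reporter, with a stated time of 24 h; on this read-out lower numbers stand for an effect already at smaller amounts and higher numbers for an effect only at larger amounts of compound; compound 1 stands at "not determined" (no result reported) there. Among the compounds with values here, compound 2 `COc1ccc(CN(CC(=O)OC(C)(C)C)Cc2ccc([N+](=O)[O-])s2)cc1` is the only member with a number: in this assay compound 2 gives 2900 nM, so it stands alone and nothing can be said of its rank. Compound 3 `CC(C)(C)OC(=O)CN(Cc1ccc(F)cc1)Cc1ccc([N+](=O)[O-])s1` carries the change (fluoro in place of methoxy on an aromatic carbon), fluoro in place of methoxy on an aromatic carbon, para to a large group. Within the data shown here, no measured pair shows the effect of such a change here. The step from compound 2 to compound 3 in this assay is expected to be a 1.0-fold higher number from compound 2 to compound 3 (0.01 log units; within the scatter), that is, no shift beyond the usual scatter. Compound 3 is therefore estimated at 3000 nM in this assay, within a range from 1000 nM to 9000 nM.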

Compound 3, half-maximal effective concentration: 2000 nM
Compound 3: the middle estimate sits 1.5-fold (0.18 log units) above what was measured; low and high end bracket the measured number.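

In this assay, the move from 4-methoxybenzyl to 4-fluorobenzyl gives a 1.5-fold lower number from compound 2 to compound 3 (0.16 log units; within the scatter), so this aromatic carbon accepts the exchange with no shift beyond the usual scatter. Within the data shown here, this is the first measured pair at this position, and it shows that a number of the same order remains when methoxy, with its 1 hydrogen-bond acceptor, gives way to the smaller fluoro, with 0 hydrogen-bond acceptors. Nothing available explains why the two groups read alike.

Compound 1, without a group at this carbon, stands at "not determined" (no result reported), so the contribution of either group relative to the unsubstituted benzyl cannot be read. On these data alone, whether an amine or a longer alkoxy chain at this carbon, or a carboxylic acid in place of the tert-butyl ester, would keep this level remains open.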